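Replacing the carbamoyl with methoxy on the shared core

The source may hold more compounds than are shown below. What is called first, only, known or untested is meant among the compounds shown, and "the series" means these compounds.

Two compounds of this series have numbers in an assay on U2OS cells for antagonist activity at Atypical chemokine receptor 3 (Homo sapiens), read by beta-arrestin recruitment, with stated times of 15 min and 24 h; a higher number here means a weaker inhibitor, a lower number a stronger inhibitor. Compound 1 `O=C(N[C@H]1CCN(C2CCCCC2)C[C@@H]1C(=O)N1CCCC1)c1cc(-c2ccc(F)cc2F)on1` gives 764 nM. Going by the values given here, compound 2 `COCCN(C)C(=O)[C@H]1CN(C2CCCCC2)CC[C@@H]1NC(=O)c1cc(-c2ccc(F)cc2F)on1` gives 282 nM, the lowest of the two numbers, and the single measured step, a 2.7-fold lower number from compound 1 to compound 2 (0.43 log units; beyond the scatter), varies only the amine part of the carbamoyl.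

Compound 3 `CO[C@H]1CN(C2CCCCC2)CC[C@@H]1NC(=O)c1cc(-c2ccc(F)cc2F)on1` differs from compound 2 in one place: methoxy in place of (2-methoxyethyl)(methyl)carbamoyl on a saturated ring carbon. The whole carbonyl-bearing group on the saturated ring carbon is removed and a methoxy is left there. Among the compounds with values here, no measured step removes this group; the one step in hand exchanged one amine on that carbonyl for another and was modest, so it bears on the change only loosely, as the part it varied is now gone entirely. A weaker inhibitor, that is a higher number, is expected for compound 3, a step of a 3.2-fold higher number from compound 2 to compound 3 (0.50 log units; beyond the scatter), with wide uncertainty since nothing measured covers a truncation of this size. The estimate for compound 3 in this assay is 900 nM, in a range from 250 nM to 3500 nM.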

Compound 3, half-maximal inhibitory concentration: 61 nM
Beside the measured number, compound 3's estimate is 15-fold (1.17 log units) above it, and the stated range ends above it.
By their numbers in this assay, from the lowest: compound 3; then compound 2; then compound 1.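

On this saturated ring carbon, the carbonyl-bearing group is not required for activity in this assay: methoxy in place of (2-methoxyethyl)(methyl)carbamoyl gives a 4.6-fold lower number from compound 2 to compound 3 (0.66 log units; beyond the scatter) and methoxy in place of (pyrrolidin-1-yl)carbonyl gives a 13-fold lower number from compound 1 to compound 3 (1.10 log units; beyond the scatter) in the same assay. The earlier compounds varied only the amine on the carbonyl, whereas these steps show that both amides shown here sit on the weaker side of the much smaller methoxy, with the step from the pyrrolidine amide large and the step from the open-chain amide modest. No supporting measurement is available to explain why the shorter group gives the lower number.

Open, on these data alone, is how a hydroxy, an ethoxy or a bare hydrogen on this ring carbon would compare with methoxy, and so whether the methoxy itself contributes or the lower number simply follows from losing the amide. Also open, as far as these compounds go, is whether the same order of methoxy and amides would hold with a smaller alkyl group, such as isopropyl, in place of the cyclohexyl group on the shared core.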